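Nitro for Methyl on the Amide Aryl Ring

The compounds below may be only part of what the source reports. "The series", "measured", "known", "first", "only" and "open" are said of these compounds alone.

Compound 2 `Cc1cccc(NC(=O)c2ccc(/N=N\c3c[nH]c4ccccc34)cc2)c1` carries a methyl on the aryl ring attached to the amide nitrogen. Going by the values given here, in a functional assay on MCF7 cells (Homo sapiens) for inhibition, read by MTT assay, with a stated time of 72 h (on this read-out lower numbers stand for stronger inhibition and higher numbers for weaker inhibition), compound 2 gives 73400 nM, the lowest of the two numbers measured so far. Its nearest neighbour is compound 1 `COc1ccccc1NC(=O)c1ccc(/N=N\c2c[nH]c3ccccc23)cc1`, which in this assay gives 86500 nM; the step of a 1.2-fold lower number from compound 1 to compound 2 (0.07 log units; within the scatter) is within the scatter, so the two cannot be told apart.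

Compound 3 `O=C(Nc1cccc([N+](=O)[O-])c1)c1ccc(/N=N\c2c[nH]c3ccccc23)cc1` differs from compound 2 in one place: nitro in place of methyl on an aromatic carbon, on an aromatic carbon of a six-membered aromatic ring of carbon only, meta to a large group. Among the compounds with values here, the only measured step, a 1.2-fold lower number from compound 1 to compound 2 (0.07 log units; within the scatter), also changed the group on this same ring and produced no change beyond the scatter. Within the data shown here, that step is the only evidence that bears here, and it concerns a different pair of groups. The expectation for compound 3 is therefore a step of a 1.0-fold lower number from compound 2 to compound 3 (0.02 log units; within the scatter), no larger than the scatter, in either direction. The estimate for compound 3 in this assay is 70000 nM, with a range from 30000 nM to 160000 nM.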

Compound 3, half-maximal inhibitory concentration: 51900 nM
Estimate against measurement, compound 3: 1.3-fold (0.13 log units) above, within the range that was stated.
By their numbers in this assay, from the lowest: compounds 3, 2 and 1 (each within the scatter of the next).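

In this assay the exchange of methyl for nitro on this ring gives a 1.4-fold lower number from compound 2 to compound 3 (0.15 log units; within the scatter) and so shows that a group of 3 heavy atoms and 2 hydrogen-bond acceptors can take the place of a group of 1 heavy atom without a step that stands clear of the scatter. Set against the 2-methoxyphenyl group, the 3-nitrophenyl group gives a 1.7-fold lower number from compound 1 to compound 3 (0.22 log units; within the scatter) and so adds a second step of this kind, which means that the three aryl groups on the amide nitrogen still cannot be told apart in this read-out. Nothing measured here accounts for this flat result or tells what the nitro group does at this place.

On these data alone, whether an amine or a carboxylic acid on the same ring would give a step beyond the scatter remains open. Also open, as far as these compounds go, is whether a change in the shared core, rather than on this ring, would separate compounds more clearly than these three aryl groups do.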